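A few compounds are considered here, and "the series" means these few. Any claim that something is new, unique, unknown or untested is made for them only; others in the source may bear on it.

Measured so far in an ADME assay on microsomes from liver (Homo sapiens), read by LC-MS, using NADPH, with a stated time of 10 min, tested at 0.5 uM; a lower number here means that less of the compound is left, a higher number that more of the compound is left:

compound 1 `Cc1nc2cc(-c3cccc(Oc4ccccc4)c3)nn2c(-c2cc(F)c3c(c2C)CCCO3)c1C(OC(C)(C)C)C(=O)O`: 100%
compound 2 `Cc1nc2cc(-c3cccc(-c4ccccc4)c3)nn2c(-c2cc(F)c3c(c2C)CCCO3)c1[C@H](OC(C)(C)C)C(=O)O`: 78%

Compound 2 has the lower of the two numbers in this assay. Compound 1 stands higher, by a gap beyond the usual scatter. Within the data shown here, with only two measured compounds and no single-place step between them, the series offers no measured step to carry over.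

Next in line is compound 3 `Cc1nc2cc(-c3cccc(-c4ccccc4)c3)nn2c(-c2cc(F)c3c(c2C)CCCO3)c1C(OC(C)(C)C)C(=O)O`, to be measured in this assay. The change from compound 2 is the two compounds have the same atoms and bonds; at least one stereo element is drawn with a configuration in one of them and without one in the other: 1 of 1 stereo elements differ; a stereocentre at a saturated chain carbon is drawn S in compound 2 and without a configuration in compound 3. The two compounds have the same atoms and bonds, and a stereocentre at a saturated chain carbon is drawn S in compound 2 and without a configuration in compound 3. Among the measured compounds shown here, no measured compound shows what this difference does in this assay.

The expectation therefore rests on compound 2 with its value of 78% (the closest structure available). The expected step of a number 2 percentage points higher from compound 2 to compound 3 (within the scatter) is none beyond the scatter, in either direction. For compound 3 the estimated value is 80%, with an expected range from 66% to 94%.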

Compound 3, percent of the compound remaining: 86%
Beside the measured number, compound 3's estimate is 6 percentage points below it; the measured number falls inside the stated range.
By their numbers in this assay, from the lowest: compounds 2 and 3 (each within the scatter of the next); then compound 1.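

In this assay, two single-place comparisons now exist for the series. At the saturated chain carbon, the centre drawn S in compound 2 and without a configuration in compound 3 gives a number 8 percentage points higher from compound 2 to compound 3 (within the scatter), so this difference in drawing does not separate the two compounds in percent remaining. Phenyl in place of phenoxy on an aromatic carbon gives a number 14 percentage points lower from compound 1 to compound 3 (beyond the scatter), and this isolates a change that compounds 1 and 2, which differ in two places, could not isolate, while the stereo comparison carries one qualification: the fact that one of compounds 2 and 3 is drawn with a defined configuration and the other without, at the place where they differ.

The compounds shown leave open how a piperidine or a benzyloxy group on that aromatic carbon would read in this assay, and whether either would stand with compound 1 or with compound 3. They also leave open the R form at the chain carbon and the effect of a methoxy group in place of the tert-butoxy group on the percent remaining.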